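The source may report more compounds than this note shows. Statements on the series, on what has been measured and on what is new or still open speak of the compounds shown alone.

Measured compounds in a functional assay on SNB-19 cells (Homo sapiens) for antiproliferative activity; a higher number here means a weaker inhibitor of growth, a lower number a stronger inhibitor of growth:
compound 1 `CC(=O)Nc1ccc(S(=O)(=O)NNC(=O)c2cccnc2Nc2ccc(Cl)cc2)cc1`: > 100000 nM
compound 2 `O=C(NNS(=O)(=O)c1ccc(F)cc1)c1cccnc1Nc1ccc(Cl)cc1Cl`: > 100000 nM

Compound 1 stands at a limit of this assay rather than at a number, and in this assay compound 1 gives > 100000 nM. Compound 2 also sits at a limit, giving > 100000 nM. Both values share (the limit of > 100000 nM in this assay, at which 2 of the 2 values shown sit). Compound 3 `O=C(NNS(=O)(=O)c1ccc(Cl)cc1Cl)c1cccnc1Nc1ccc(Cl)cc1` differs from compound 1 by 2,4-dichlorophenyl in place of 4-acetamidophenyl on a sulfonyl sulfur. Going by the values given here, with no measured step at hand and compound 1 itself only at a limit, the step is expected to be none beyond the scatter, a number no higher from compound 1 to compound 3 (the limit leaves the size open). Compound 3 is therefore estimated at 100000 nM, within 30000 nM to 300000 nM.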

Compound 3, concentration for total growth inhibition: 100000 nM
For compound 3 middle estimate and measured number coincide at the digits printed, within the range that was stated.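

In this assay compound 3 gives 100000 nM, and the step is a number no higher from compound 1 to compound 3 (the limit leaves the size open) with 2,4-dichlorophenyl in place of 4-acetamidophenyl on a sulfonyl sulfur. Compound 1 gives > 100000 nM, which is a limit of the assay. The size of the change from 4-acetamidophenyl to 2,4-dichlorophenyl therefore cannot be read, and the number for compound 3 coincides with the figure of the limit: the limit of > 100000 nM in this assay, at which 2 of the 3 values shown sit.

The compounds shown leave open whether any group at this position gives a clearly lower number. An aminophenyl or carboxyphenyl group, or a longer alkyl chain on the sulfonyl sulfur, would test this.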